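Swapping the quinoxaline for an aryl-triazole on compound 1

A few compounds are considered here, and "the series" means these few. Any claim that something is new, unique, unknown or untested is made for them only; others in the source may bear on it.

Compound 1 `CC(C)(C)c1ccc(-c2nc3c(N4CCN(Cc5cccc6nccnc56)CC4)cccc3[nH]2)cc1` is the strongest of the three compounds in a functional assay on cells for antagonist activity at Gonadotropin-releasing hormone receptor (Homo sapiens), read by FLIPR and calcium flux, with a stated time of 15 min (a higher number here means a weaker inhibitor, a lower number a stronger inhibitor), where compound 1 gives 631 nM. Compound 3 `COc1cc(OC)c(NC(=O)c2ccc(Cc3cc4c(cc3C)C(C)(C)CCC4(C)C)o2)c(OC)c1` gives 1000 nM, a gap from compound 1 that lies within the scatter. Compound 2 `CC(C)(C)OC(=O)N[C@@H](Cn1cc(CN2CCN(c3cccc4[nH]c(-c5ccc(C(C)(C)C)cc5)nc34)CC2)nn1)C(=O)O`, which also carries a triazole on the piperazine, gives 10000 nM, well beyond the scatter from compound 1. Compound 4 `CC(C)(C)c1ccc(-c2nc3c(N4CCN(Cc5cn(-c6ccc(F)cc6)nn5)CC4)cccc3[nH]2)cc1` differs from compound 1 by 1-(4-fluorophenyl)-1H-1,2,3-triazol-4-yl in place of quinoxalin-5-yl on a saturated chain carbon bound to an amine nitrogen in a ring. Going by the values given here, no measured pair isolates this change, so the expected step from compound 1 to compound 4 is uncertain; a modest loss is expected, a 2.4-fold higher number from compound 1 to compound 4 (0.38 log units; beyond the scatter), partly because the other triazole-bearing compound 2 gives 10000 nM. Compound 4 is therefore estimated at 1500 nM, between 400 nM and 6000 nM.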

Compound 4, half-maximal inhibitory concentration: 20000 nM
Beside the measured number, compound 4's estimate is 13-fold (1.12 log units) below it; measured number outside the range, above it.
By their numbers in this assay, from the lowest: compounds 1 and 3 (each within the scatter of the next); then compounds 2 and 4 (each within the scatter of the next).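

At the saturated chain carbon bound to an amine nitrogen in a ring, the group proves to matter in this assay: 1-(4-fluorophenyl)-1H-1,2,3-triazol-4-yl in place of quinoxalin-5-yl gives a 32-fold higher number from compound 1 to compound 4 (1.50 log units; beyond the scatter) on an otherwise unchanged structure. Going by these compounds alone, this is the first single-place step at this position, and this aryl-triazole does not stand in for the quinoxaline. Nothing available accounts for the loss. The compounds shown leave open whether it follows the triazole ring or the 4-fluorophenyl on it. They also leave open how an unsubstituted phenyl or a methoxy group on that ring would read.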